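Swapping dimethylamino for methyl in compound 3

The compounds below may be only part of what the source reports. "The series", "measured", "known", "first", "only" and "open" are said of these compounds alone.

Measured in a functional assay on HL-60 cells (Homo sapiens) for antiproliferative activity, read by MTT assay, with a stated time of 72 h; on this read-out higher numbers stand for weaker inhibition and lower numbers for stronger inhibition:
- Compound 1 `COc1cc(-c2nc(N(C)C)sc2-c2ccc3ccccc3c2)cc(OC)c1OC`: 2570 nM
- Compound 2 `COc1cc(-c2nc(N(C)C)sc2-c2ccc(C(F)(F)F)cc2)cc(OC)c1OC`: > 10000 nM (a limit of the assay, not a number)
- Compound 3 `CCOc1ccc(-c2sc(N(C)C)nc2-c2cc(OC)c(OC)c(OC)c2)cc1`: 303 nM

Only two of these three results are true numbers, and compound 3 has the lower one. Going by the values given here, the gap to its one numeric neighbour is an 8.5-fold lower number from compound 1 to compound 3 (0.93 log units; beyond the scatter). Against the limit, the comparison gives an at least 33-fold lower number from compound 2 to compound 3 (1.51 log units; beyond the scatter).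

Compound 4 `CCOc1ccc(-c2sc(C)nc2-c2cc(OC)c(OC)c(OC)c2)cc1` differs from compound 3 in a single place: methyl in place of dimethylamino on an aromatic carbon. In words, methyl stands in place of dimethylamino. Among the compounds with values here, none of the measured steps touches this place, since all three exchange a different group, so they give no direction for this change. Within the data shown here, they show only that one exchange can move the numbers in this small set a long way, as in an at least 3.8-fold higher number from compound 1 to compound 2 (0.59 log units; beyond the scatter). That calls for a wide range in this assay, but with no direct guide, the central expectation is no step beyond the scatter, and a shift either way remains possible. The estimated change is a 1.4-fold lower number from compound 3 to compound 4 (0.14 log units; within the scatter). For compound 4 the estimated value is 220 nM, with an expected range of 30 nM to 1600 nM.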

Compound 4, half-maximal inhibitory concentration: 253 nM
The estimate for compound 4 lay 1.2-fold (0.06 log units) below the measured number, within the range that was stated.
By their numbers in this assay, from the lowest: compounds 4 and 3 (each within the scatter of the next); then compound 1. At a limit, above all of these: compound 2.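

In this assay, methyl in place of dimethylamino gives a 1.2-fold lower number from compound 3 to compound 4 (0.08 log units; within the scatter) and so the two compounds cannot be told apart. Going by these compounds alone, none of the earlier steps touched this place on the ring, next to the ring nitrogen and next to the ring sulfur, and this pair shows that, with the 4-ethoxyphenyl group in place, the three heavy atoms of dimethylamino and its one hydrogen-bond acceptor can give way to the single carbon of methyl with no shift beyond the scatter, unlike the exchanges of the aromatic group, which all moved the number beyond it. Nothing measured here gives a reason why these two groups read alike.

This single pair does not say whether a primary amine, a longer chain such as propyl, or a carboxylic acid would be tolerated at this place as well. It also leaves open whether methyl and dimethylamino would still read alike with the naphthalen-2-yl group of compound 1 or the 4-(trifluoromethyl)phenyl group of compound 2 in place of 4-ethoxyphenyl.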